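The source may report more compounds than this note shows. Statements on the series, on what has been measured and on what is new or still open speak of the compounds shown alone.

Measured so far:
Compound 1 `CC(=O)OC[C@H]1O[C@H](OC[C@H](Cn2cc(-c3ccc(-c4noc(NC5CCCCC5)n4)cc3)nn2)OC(C)=O)C=C[C@@H]1OC(C)=O` gives 79.8 ug/mL in an ADME assay on HepG2 cells (Homo sapiens) for cytotoxicity, read by MTT assay, with a stated time of 48 h; on this read-out lower numbers stand for higher toxicity in this test and higher numbers for lower toxicity in this test.
Compound 2 `CC(=O)OC[C@H]1O[C@H](OC[C@@H](Cn2cc(CN(c3nc(-c4cccc(C)c4)no3)C3CCCCC3)nn2)OC(C)=O)C=C[C@@H]1OC(C)=O` gives 39.2 ug/mL in this assay.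
Compound 3 `CC(=O)OC[C@H]1O[C@H](OC[C@@H](CN=[N+]=[N-])OC(C)=O)C=C[C@@H]1OC(C)=O` reaches only a limit of this assay, > 200 ug/mL, not a number.

Among the two numbers, compound 2 stands lowest in this assay, and compound 1 stands above it by a gap beyond the usual scatter. Compound 4 `CC(=O)OC[C@H]1O[C@H](OC[C@@H](Cn2cc(CN(c3nc(-c4ccc(F)cc4)no3)C3CCCCC3)nn2)OC(C)=O)C=C[C@@H]1OC(C)=O` keeps the whole of compound 2 apart from one change: 4-fluorophenyl in place of 3-methylphenyl on an aromatic carbon. Among the measured compounds shown here, no measured pair isolates this exchange, so the step of a 1.1-fold higher number from compound 2 to compound 4 (0.03 log units; within the scatter) is expected to stay within the scatter, with no clear direction. Compound 4 is therefore estimated to give 42 ug/mL in this assay, most likely between 18 ug/mL and 100 ug/mL.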

Compound 4, half-maximal cytotoxic concentration: 28.8 ug/mL
Compound 4: middle estimate off by 1.5-fold (0.16 log units), on the high side; low and high end bracket the measured number.
By their numbers in this assay, from the lowest: compounds 4 and 2 (each within the scatter of the next); then compound 1. At a limit, above all of these: compound 3.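

Compound 2 and compound 4 form the only pair shown that differs in one place, so the exchange of 3-methylphenyl for 4-fluorophenyl can be read directly. In this assay it gives a 1.4-fold lower number from compound 2 to compound 4 (0.13 log units; within the scatter) and thus no clear change, so at this aromatic carbon the two substituted phenyl groups read alike. Nothing at hand bears on this step.

Open, from the compounds shown here alone, is whether a phenyl ring carrying an amine or a carboxylic acid at this position would shift the number beyond the scatter. Also open, going by these compounds, is how a longer alkyl chain in place of the ring would read.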